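Nitrile to longer alkyl at the chain end of the shared core

A few compounds are considered here, and "the series" means these few. Any claim that something is new, unique, unknown or untested is made for them only; others in the source may bear on it.

Compound 3 `N#CCCCCc1nc(O)cc(O)n1` gives 55.2% in a functional assay on HEK293 cells for agonist activity at G-protein coupled receptor 84 (Homo sapiens), read by calcium flux (on this read-out higher numbers stand for larger maximal responses and lower numbers for smaller maximal responses), the lowest of the three numbers: compound 1 `CCCCCc1nc(O)cc(O)n1` gives 84.9% and compound 2 `CC(C)CCCc1nc(O)cc(O)n1` gives 85.6%. Compound 4 `CCCCCCCCc1nc(O)cc(O)n1` differs from compound 3 by butyl in place of cyano on a saturated chain carbon, four bonds along the chain from an aromatic carbon. For the measured compounds named here, the steps that bear on this are a number 29.7 percentage points lower from compound 1 to compound 3 (beyond the scatter) and a number 30.4 percentage points lower from compound 2 to compound 3 (beyond the scatter), each bringing in the cyano group, while a number 0.7 percentage points higher from compound 1 to compound 2 (within the scatter) shows that methyl in place of hydrogen on the chain hardly alters the response. Removing the cyano group and extending the chain with butyl is therefore expected to undo that loss, so a step of a number 29.8 percentage points higher from compound 3 to compound 4 (beyond the scatter) is estimated. For compound 4 the estimate is 85%, with a range from 65% to 100%.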

Compound 4, largest response reached (reported as percent of maximum), in percent of the reference or control that the assay uses: 110%
The estimate for compound 4 lay 25 percentage points below the measured number; the measured number lies above the stated range.
By their numbers in this assay, from the lowest: compound 3; then compounds 1 and 2 (each within the scatter of the next); then compound 4.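

In this assay butyl in place of cyano does more than recover the level of the alkyl compounds: the change is a number 54.8 percentage points higher from compound 3 to compound 4 (beyond the scatter) and the result also passes both of them, with a number 25.1 percentage points higher from compound 1 to compound 4 (beyond the scatter) and a number 24.4 percentage points higher from compound 2 to compound 4 (beyond the scatter) as the remaining steps. Extra alkyl carbon at the chain end can therefore raise the response, although compound 2, with its methyl branch, stays level with compound 1. Nothing available accounts for this rise. From the compounds shown here alone, whether a longer chain raises the response further remains open, as does how an amine or a carboxylic acid at the chain end would compare.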